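Swapping an aryl for a small amide on a ring nitrogen

A few compounds are considered here, and "the series" means these few. Any claim that something is new, unique, unknown or untested is made for them only; others in the source may bear on it.

Of the compounds shown here, three share one core and have been tested in a functional assay on Mahlavu cells (Homo sapiens) for antiproliferative activity, read by sulforhodamine B assay, with a stated time of 72 h; on this read-out lower numbers stand for stronger inhibition and higher numbers for weaker inhibition. Compound 1, `FC(F)(F)c1ccc(CN2CCN(Cc3cc(-c4ccc(OCc5ccccc5Cl)cc4)on3)CC2)cc1`, gives 3200 nM. Among the measured compounds shown here, compound 2, `N#Cc1ccc(COc2ccc(-c3cc(CN4CCN(Cc5ccc(C(F)(F)F)cc5)CC4)no3)cc2)cc1`, gives 4300 nM; the only single-site step measured is a 1.3-fold higher number from compound 1 to compound 2 (0.13 log units; within the scatter), which concerns the group on a saturated chain carbon bound to an oxygen on an aromatic ring. Compound 3, `N#Cc1cccc(COc2ccc(-c3cc(CN4CCN(c5ccc(C(F)(F)F)cn5)CC4)no3)cc2)c1`, gives 1300 nM and stands lowest of the three, with compound 1 nearest and compound 2 furthest, both gaps beyond the scatter.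

Compound 4, `N#Cc1cccc(COc2ccc(-c3cc(CN4CCN(C(=O)C5CC5)CC4)no3)cc2)c1`, keeps the 3-cyanophenyl part of compound 3 and changes only the group on the amine nitrogen in a ring: cyclopropylcarbonyl in place of 5-(trifluoromethyl)pyridin-2-yl on an amine nitrogen in a ring. For the measured compounds named here, no measured step touches this position. Going by the values given here, compounds 1 and 2 carry a different substituent there than compound 3, but they also differ at another site, so their values show only that the ring-nitrogen group is not fixed across the set, not how much it matters on its own.

Among the compounds with values here, with no comparable step to lean on, the direction in this assay is open; the expectation is a weaker number, estimated as a 3.1-fold higher number from compound 3 to compound 4 (0.49 log units; beyond the scatter). Compound 4 is therefore expected to give about 4000 nM, within a range from 1000 nM to 16000 nM.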

Compound 4, half-maximal inhibitory concentration: 4400 nM
The estimate for compound 4 lay 1.1-fold (0.04 log units) below the measured number, and the stated range covers the measured number.
By their numbers in this assay, from the lowest: compound 3; then compounds 1, 2 and 4 (each within the scatter of the next).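

Among the compounds shown here, this is the first step measured at the amine nitrogen in a ring with the rest of the molecule held fixed: in this assay the change gives a 3.4-fold higher number from compound 3 to compound 4 (0.53 log units; beyond the scatter) and so shows that the group on this nitrogen matters on its own. The group that leaves is 5-(trifluoromethyl)pyridin-2-yl, with 10 heavy atoms and a six-membered aromatic ring, while the group that enters is cyclopropylcarbonyl, with 5 heavy atoms and a three-membered non-aromatic ring, and inhibition is weaker with the entering group. No measurement at hand says which of the differences between these two groups accounts for the step.

On these data alone, a single pair cannot separate the loss of the aromatic ring from the arrival of the carbonyl, so it stays open whether a simple pyridin-2-yl without the trifluoromethyl, a benzoyl or an acetyl on this nitrogen would fall nearer compound 3 or compound 4. As far as these compounds go, it is also open whether the same swap would give a step of similar size with 4-cyanophenyl or 2-chlorophenyl in place of the 3-cyanophenyl part.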